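Swapping an Anilide for a Pyrrolidine Amide

This account rests on a few compounds, and the source may have more. Where it says the series, first, only, none or still open, it means among the compounds named here.

Compound 1 `COc1ccc(C[C@H]2COC(=O)[C@@H]2Cc2ccc(OCC(=O)Nc3ccccc3)c(OC)c2)cc1OC` carries a (phenylcarbamoyl)methoxy group on the shared core, and its toxicity toward cultured cells was examined in an ADME assay on HeLa cells (Homo sapiens) for cytotoxicity, read by MTT assay; on this read-out lower numbers stand for stronger inhibition and higher numbers for weaker inhibition. In this assay compound 1 gives >= 600000 nM, which is a limit of the assay rather than a measured number. Two related compounds, compound 2 `COc1ccc(C[C@H]2COC(=O)[C@@H]2Cc2ccc(OCc3cn(Cc4ccccc4F)nn3)c(OC)c2)cc1OC` and compound 3 `COc1ccc(-n2cc(COc3ccc(C[C@H]4C(=O)OC[C@@H]4Cc4ccc(OC)c(OC)c4)cc3OC)nn2)cc1`, were tested alongside it. In this assay compound 2 gives >= 600000 nM, again a limit. Compound 3 gives >= 600000 nM in this assay, also a limit. Within the data shown here, the one single-point change among the measured compounds, a step that the two limits leave unreadable from compound 2 to compound 3, cannot be sized because of the limit of >= 600000 nM in this assay, at which 3 of the 3 values shown sit.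

Compound 4 `COc1ccc(C[C@H]2COC(=O)[C@@H]2Cc2ccc(OCC(=O)N3CCCC3)c(OC)c2)cc1OC` differs from compound 1 in one place: pyrrolidin-1-yl in place of anilino on a carbonyl carbon. Among the measured compounds shown here, no measured step covers this change, and the only measured step is unreadable. Because (the limit of >= 600000 nM in this assay, at which 3 of the 3 values shown sit), compound 4 is expected to sit at that same limit, so the step of a number no higher from compound 1 to compound 4 (the limit leaves the size open) is expected to be none beyond the scatter. Compound 4 is therefore estimated at 600000 nM, with a range from 300000 nM to 1200000 nM.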

Compound 4, half-maximal inhibitory concentration: >= 600000 nM
Compound 4 gave a limit, no number (the forecaster's own chance of this, stated with the estimate: 85%); the middle value lies on the limit itself.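

Compound 1 and compound 4 both sit at a limit rather than at a number, so no size can be read for the swap between them, because the assay gives no measured value here: the limit of >= 600000 nM in this assay, at which 4 of the 4 values shown sit. Going by these compounds, what remains open is whether anilino and pyrrolidin-1-yl differ at all in their effect on these cells, since the actual value behind each limit is unknown.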